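The compounds below may be only part of what the source reports. "The series", "measured", "known", "first", "only" and "open" are said of these compounds alone.

Three compounds share one core, built from a hindered phenol carrying two tert-butyl groups, linked through an amide to a piperidine that bears a benzyl-type group on its ring nitrogen. Compound 1 has the structure `CC(C)(C)c1cc(CCC(=O)NCCC2CCN(Cc3ccccc3)CC2)cc(C(C)(C)C)c1O`, with a saturated linker to the amide; compound 2, `COc1ccc(CN2CCC(CCNC(=O)/C=C/c3cc(C(C)(C)C)c(O)c(C(C)(C)C)c3)CC2)cc1`, and compound 3, `Cc1ccccc1CN1CCC(CCNC(=O)/C=C/c2cc(C(C)(C)C)c(O)c(C(C)(C)C)c2)CC1`, carry an unsaturated linker instead and differ only in the group on the ring nitrogen. In an assay on isolated protein for inhibition of Amine oxidase [flavin-containing] A (Homo sapiens), read by fluorescence, with stated times of 15 min and 20 min (on this read-out lower numbers stand for stronger inhibition and higher numbers for weaker inhibition), compound 1 gives 94100 nM. In this assay compound 2 gives 72500 nM, and compound 3 gives 69300 nM. The swap of the aryl group, a 1.0-fold lower number from compound 2 to compound 3 (0.02 log units; within the scatter), leaves the number essentially unchanged. Compound 3 thus shows the lowest of the three numbers, yet its gaps to compound 2 and to compound 1 both sit within the scatter, so no one of the three can be called more potent than another.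

Compound 4, `CC(C)(C)c1cc(/C=C/C(=O)NCCC2CCN(Cc3ccccc3F)CC2)cc(C(C)(C)C)c1O`, is the next step from compound 3: fluoro in place of methyl on an aromatic carbon. Among the measured compounds shown here, the one measured step that bears on this position, the change of the aryl group from compound 2 to compound 3, stayed within the scatter, so a small change at the same place is expected to do the same. The step of a 1.0-fold higher number from compound 3 to compound 4 (0.00 log units; within the scatter) is therefore expected to show no change beyond the scatter. Compound 4 is estimated to give 70000 nM in this assay, with a range from 35000 nM to 140000 nM.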

Compound 4, half-maximal inhibitory concentration: 60200 nM
Estimate against measurement, compound 4: 1.2-fold (0.07 log units) above, and the stated range covers the measured number.
By their numbers in this assay, from the lowest: compounds 4, 3, 2 and 1 (each within the scatter of the next).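

In this assay, putting fluoro in place of methyl on this aromatic carbon, ortho to a large group, gives a 1.2-fold lower number from compound 3 to compound 4 (0.06 log units; within the scatter), so this exchange of one heavy atom for another leaves no change that can be told from the scatter. The wider exchange of the whole group gives a 1.2-fold lower number from compound 2 to compound 4 (0.08 log units; within the scatter), which means that 4-methoxyphenyl, 2-methylphenyl and 2-fluorophenyl now all stand within the scatter of one another, and none of the three can be ranked above the others. Nothing available speaks to why the number stays put across these changes.

Going by these compounds, each of these aryl groups carries a single substituent, so it remains open whether this ring would answer to something quite different, such as an amine, a carboxylic acid or a longer chain in the same place. Among the compounds shown, the saturated linker of compound 1 appears only with a plain benzyl group, so the effect of the linker cannot be separated from that of the group on the ring nitrogen; a saturated linker paired with 2-fluorobenzyl would allow that comparison.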